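The compounds below may be only part of what the source reports. "The series", "measured", "known", "first", "only" and "open" are said of these compounds alone.

Measured compounds:

Compound 1 `O[C@@H]1[C@@H](O)[C@H](Oc2ccc(S)c3ccccc23)OC[C@H]1O` gives 70 uM in an ADME assay on HFL1 cells (Homo sapiens) for antiproliferative activity, read by crystal violet staining, with a stated time of 96 h; a lower number here means that less compound is needed, a higher number that more compound is needed for the effect.
Compound 2 `O[C@@H]1[C@@H](O)[C@H](Oc2cccc3cccc(S)c23)OC[C@H]1O` gives 60 uM in this assay.
Compound 3 `CCCSc1ccc(O[C@@H]2OC[C@@H](O)[C@H](O)[C@H]2O)c2ccccc12` gives 30 uM in this assay.

Compound 1 and compound 2 are built from the same atoms joined differently; the difference between the two cores is not broken down here. Their two values lie within the scatter of each other, so nothing can be said about which of them needs less compound.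

Compound 3 is compound 1 with one change, (propyl in place of hydrogen on a sulfur). This change made a 2.3-fold lower number from compound 1 to compound 3 (0.37 log units; beyond the scatter), a modest step to a lower number, meaning less compound was needed for the half-maximal effect.

Compound 4 `CCCSc1cccc2cccc(O[C@@H]3OC[C@@H](O)[C@H](O)[C@H]3O)c12` has not yet been measured. It is compound 2 with the same change, (propyl in place of hydrogen on a sulfur). In both pairs the place is a sulfur whose other neighbours are aromatic carbon, so the change is the same in kind and in place, differing only in the core it is made on.

For the measured compounds named here, because the one measured instance of this change gave a 2.3-fold lower number from compound 1 to compound 3 (0.37 log units; beyond the scatter), a step of similar size is expected from compound 2 to compound 4 in this assay, namely a 2.3-fold lower number from compound 2 to compound 4 (0.36 log units; beyond the scatter). This rests on a single measured pair, so the expectation is tentative; it is not known whether the change behaves the same on the core of compound 2. Starting from the value of compound 2, compound 4 is therefore estimated at 26 uM in this assay, with a plausible range from 12 uM to 60 uM.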

Compound 4, concentration for half-maximal effect: 100 uM
Compound 4: the middle estimate sits 3.8-fold (0.59 log units) below what was measured; measured number above the stated range.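

On the core of compound 2, propyl in place of hydrogen on a sulfur gives a 1.7-fold higher number from compound 2 to compound 4 (0.22 log units; within the scatter) in this assay, so on this core the change cannot be told apart from no change at all. Set beside the earlier pair, the same change does not carry over from one core to the other, even though it sits on a sulfur whose other neighbours are aromatic carbon in both pairs: the same change on two cores in this assay, a 2.3-fold lower number (0.37 log units; beyond the scatter) from compound 1 to compound 3 and a 1.7-fold higher number (0.22 log units; within the scatter) from compound 2 to compound 4, 3.9-fold (0.59 log units) apart, beyond the scatter of two such steps. In this small series, then, a step seen on one core cannot be assumed on the other, but with a single pair per core this does not show what in the two cores lies behind the gap, nor whether the same would hold for any other change.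

The compounds shown leave open whether a shorter chain such as methyl, a longer chain such as butyl, or a chain carrying an amine or a carboxylic acid would give matching steps on the two cores when placed on the sulfur instead of propyl. They also leave open whether the gap between the two cores would grow or shrink as the chain on the sulfur changes.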